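This account rests on a few compounds, and the source may have more. Where it says the series, first, only, none or still open, it means among the compounds named here.

Values in a functional assay on HOP-92 cells (Homo sapiens) for inhibition; a higher number here means a weaker inhibitor of growth, a lower number a stronger inhibitor of growth:
- compound 1 `NC(=O)c1cc(Cl)ccc1NC(=O)COc1ccccc1`: 5700 nM
- compound 2 `NC(=O)c1cc(I)ccc1NC(=O)COc1ccccc1`: 1500 nM
- compound 3 `COc1ccc(NC(=O)COc2ccccc2)c(C(N)=O)c1`: not yet measured

Of the two measured compounds, compound 2 has the lower number, at 1500 nM, and is the stronger inhibitor of growth of the pair. The next change is methoxy in place of iodo on an aromatic carbon, meta to a carbamoyl group and para to a large group.

Within the data shown here, one measured step bears on this carbon: iodo in place of chloro, a 3.8-fold lower number from compound 1 to compound 2 (0.58 log units; beyond the scatter). This step is modest but beyond the scatter. Among the measured compounds shown here, it shows that the number in this assay can move with the group at this carbon, but no methoxy compound has been measured, so the size of the next step is uncertain. For the measured compounds named here, compound 2 at 1500 nM holds the lowest number so far, so a return toward the level of compound 1 at 5700 nM is the expectation. The expected change is a 3.3-fold higher number from compound 2 to compound 3 (0.52 log units; beyond the scatter), similar in size to the measured step but opposite in direction. The estimated value for compound 3 is 5000 nM, with an expected range of 1800 nM to 15000 nM.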

Compound 3, concentration for 50% growth inhibition: 414 nM
Compound 3: the middle estimate sits 12-fold (1.08 log units) above what was measured, outside the stated range (below it).
By their numbers in this assay, from the lowest: compound 3; then compound 2; then compound 1.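

In this assay, among these compounds, the group on this aromatic carbon, para to a large group, can move the number further than the two halogens alone indicated: the step to methoxy gives a 3.6-fold lower number from compound 2 to compound 3 (0.56 log units; beyond the scatter) and, against the chloro compound, a 14-fold lower number from compound 1 to compound 3 (1.14 log units; beyond the scatter), the only large step so far. Compound 3 is therefore the strongest inhibitor of growth of the three, and the lowest number at this position belongs to a group with an oxygen and one hydrogen-bond acceptor, while iodo and chloro, with no hydrogen-bond acceptor counted, stand higher; the low end of the range is thus not tied to a heavier halogen. No measurement at hand accounts for this order.

On these data alone, three groups at one carbon give an order but no trend, and it remains open whether the oxygen matters, which a methyl or a hydroxyl at this carbon would help to separate from the size of the group. An ethoxy or a longer alkoxy chain would show whether the number keeps falling beyond methoxy, and an amine would test a different attached atom on the same core.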